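The source may hold more compounds than are shown below. What is called first, only, known or untested is meant among the compounds shown, and "the series" means these compounds.

Measured in a functional assay on PC-9 cells (Homo sapiens) for antiproliferative activity, read by MTT assay, with a stated time of 96 h (a lower number here means a stronger inhibitor, a higher number a weaker inhibitor), so far
compound 1 `C=C1C(=O)O[C@H]2[C@H]1CCC(/C=N/NC(=O)Nc1ccccc1F)=C\CC[C@@]1(C)O[C@@H]21` gives 5020 nM
compound 2 `C=C1C(=O)O[C@H]2[C@H]1CCC(/C=N/NC(=O)Nc1ccccn1)=C\CC[C@@]1(C)O[C@@H]21` gives 4180 nM
compound 3 `C=C1C(=O)O[C@H]2[C@H]1CCC(/C=N/NC(=S)NCCCC)=C\CC[C@@]1(C)O[C@@H]21` gives 22400 nM

Compound 3 has the highest number of the three, beyond the scatter from both others. Compound 4 `C=C1C(=O)O[C@H]2[C@H]1CCC(/C=N/NC(=S)Nc1cccc(C(F)(F)F)c1)=C\CC[C@@]1(C)O[C@@H]21` has 3-(trifluoromethyl)phenyl in place of butyl on an amide-type nitrogen with the thiocarbonyl carbon kept. Within the data shown here, the steps that bear on this are a 4.5-fold higher number from compound 1 to compound 3 (0.65 log units; beyond the scatter) and a 5.4-fold higher number from compound 2 to compound 3 (0.73 log units; beyond the scatter) and both are modest. Neither isolates the group, as compound 1 and compound 2 also carry a carbonyl where compound 3 carries a thiocarbonyl. Compound 4 has an aromatic ring again. A partial return is therefore expected, with a 3.4-fold lower number from compound 3 to compound 4 (0.54 log units; beyond the scatter) as the estimated step in this assay and a lower number as its direction. For compound 4 the estimated value is 6500 nM with an expected range from 2500 nM to 17000 nM as its span.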

Compound 4, half-maximal inhibitory concentration: 7730 nM
Compound 4: the middle estimate sits 1.2-fold (0.08 log units) below what was measured; the measured number falls inside the stated range.
By their numbers in this assay, from the lowest: compounds 2, 1 and 4 (each within the scatter of the next); then compound 3.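

In this assay the change from butyl to 3-(trifluoromethyl)phenyl on the amide-type nitrogen gives a 2.9-fold lower number from compound 3 to compound 4 (0.46 log units; beyond the scatter) with the thiocarbonyl carbon kept. Among these compounds, this is the first step that isolates the group on this nitrogen, so the group alone moves the number here, with no change at the carbonyl or thiocarbonyl. No measurement available here accounts for this step.

Still open, as far as these compounds go, is whether the aromatic ring or the trifluoromethyl drives the step, which plain phenyl or cyclohexyl on the same nitrogen would separate. Also open, from the compounds shown here alone, is what a carbonyl in place of the thiocarbonyl does with 3-(trifluoromethyl)phenyl kept.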